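The source may hold more compounds than are shown below. What is called first, only, known or untested is meant among the compounds shown, and "the series" means these compounds.

Compound 2 `CON(Cc1cccs1)C(=O)COc1ccc(C)cc1` belongs to a small set of amides in which a methylphenyl group is carried on one side of the carbonyl and a thiophene-bearing nitrogen on the other. In an assay on HEK293 cells for agonist activity at transient receptor potential cation channel subfamily M member 8 (Homo sapiens), read by fluorescence and calcium flux, with a stated time of 15 min (on this read-out lower numbers stand for an effect already at smaller amounts and higher numbers for an effect only at larger amounts of compound), compound 2 gives 10 nM, the higher of the two numbers reported, whereas compound 3 `Cc1ccc(/C=C/C(=O)N(Cc2cccs2)c2ccn[nH]2)cc1` gives 0.004 nM, a gap well beyond the usual scatter. Compound 1 `CCN(C(=O)COc1ccc(C)cc1)C(C)c1cccs1` is recorded only as "not active" (no number reported), without a number. Compound 4 `COCCN(Cc1cccs1)C(=O)COc1ccc(C)cc1` has not yet been measured; it differs from compound 2 by 2-methoxyethyl in place of methoxy on an amide-type nitrogen. Going by the values given here, no measured pair shows this change, so its effect is open. A modest weakening is expected, with the step of a 3.0-fold higher number from compound 2 to compound 4 (0.48 log units; beyond the scatter) estimated to stay near the scatter. Compound 4 is therefore expected at about 30 nM, within 5 nM to 300 nM.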

Compound 4, half-maximal effective concentration: 400 nM
Compound 4: middle estimate off by 13-fold (1.12 log units), on the low side, and the stated range ends below it.
By their numbers in this assay, from the lowest: compound 3; then compound 2; then compound 4.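

In this assay, going by these compounds alone, 2-methoxyethyl in place of methoxy on an amide-type nitrogen gives a 40-fold higher number from compound 2 to compound 4 (1.60 log units; beyond the scatter) and supplies the first measured step at this position. The position is therefore sensitive to this change, even though the two groups have equal counts of hydrogen-bond donors and acceptors and differ in heavy atoms. Nothing measured here explains the size of the step. The compounds shown leave open how a hydroxyethyl group, an aminoethyl group or a longer ether chain on this nitrogen would read out.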